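Aminopyridine in place of triazole on the shared core

The source may report more compounds than this note shows. Statements on the series, on what has been measured and on what is new or still open speak of the compounds shown alone.

Measured compounds in an in vitro assay on CHO cells for displacement of a labelled ligand from Bombesin receptor subtype-3 (Homo sapiens), read by scintillation counting, with a stated time of 2 h; on this read-out higher numbers stand for weaker inhibition and lower numbers for stronger inhibition:
compound 1 `CCC(C)(C)Cc1c[nH]c(CCc2ccc(-c3cccc(C)n3)cc2)n1` gives 6.3 nM
compound 2 `CCC(C)(C)Cc1c[nH]c(CCc2ccc(-n3ccnn3)cc2)n1` gives 390 nM
compound 3 `CCC(C)(C)Cc1c[nH]c(CCc2ccc(-c3ccc(F)cn3)cc2)n1` gives 19 nM

Compound 2 stands highest of the three numbers in this assay, with compound 3 nearest and compound 1 furthest. Compound 4 `CCC(C)(C)Cc1c[nH]c(CCc2ccc(-c3cccc(N)n3)cc2)n1` has not yet been measured. Its change from compound 2 is 6-aminopyridin-2-yl in place of 1H-1,2,3-triazol-1-yl on an aromatic carbon. Going by the values given here, two measured steps bear on this: the step of a 21-fold lower number from compound 2 to compound 3 (1.31 log units; beyond the scatter) and the step of a 62-fold higher number from compound 1 to compound 2 (1.79 log units; beyond the scatter), both moving between the triazolyl group and a pyridin-2-yl group on the same aromatic carbon. A large step to a lower number in this assay is therefore expected for compound 4. Its estimated step is a 26-fold lower number from compound 2 to compound 4 (1.41 log units; beyond the scatter). Compound 4 is expected to give about 15 nM in this assay, within a range from 4 nM to 60 nM.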

Compound 4, half-maximal inhibitory concentration: 7.3 nM
Estimate against measurement, compound 4: 2.1-fold (0.31 log units) above; low and high end bracket the measured number.
By their numbers in this assay, from the lowest: compounds 1 and 4 (each within the scatter of the next); then compound 3; then compound 2.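

In this assay, the 6-aminopyridin-2-yl group gives a 53-fold lower number from compound 2 to compound 4 (1.73 log units; beyond the scatter), so a hydrogen-bond donor on the pyridin-2-yl group is compatible with a low number. Amino and methyl at this place cannot be told apart, with a 1.2-fold higher number from compound 1 to compound 4 (0.06 log units; within the scatter), while the 6-aminopyridin-2-yl group gives a 2.6-fold lower number from compound 3 to compound 4 (0.42 log units; beyond the scatter). No evidence is available to explain these steps. On these data alone, how a methoxy or dimethylamino group at the same place would compare with the amino group of compound 4 remains open.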